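The source may hold more compounds than are shown below. What is called first, only, known or untested is meant among the compounds shown, and "the series" means these compounds.

Measured in an ADME assay on microsomes from liver (Rattus norvegicus, strain Sprague-Dawley) for metabolic stability, read by HPLC, using NADPH, with stated times of 5 min and 60 min, tested at 10 uM; a lower number here means that the compound disappears faster, a higher number that the compound lasts longer:
Compound 1 `CS(=O)(=O)Nc1ccc(CNC(=O)c2ccc(C34CC(C3)C4)cc2)c(Cl)c1`: 1.35 h
Compound 2 `CS(=O)(=O)Nc1ccc(CNC(=O)c2ccc(OC(F)(F)F)cc2)c(Cl)c1`: 2.47 h

Going by the values given here, with compound 2 at 2.47 h, only one comparison is available, and the two measured compounds lie within the scatter of each other: a 1.8-fold higher number from compound 1 to compound 2 (0.26 log units; within the scatter). Compound 3 `CC(C)(O)c1ccc(C(=O)NCc2ccc(NS(C)(=O)=O)cc2Cl)cc1` keeps the shared core of compound 2 and alters one group: 1-hydroxy-1-methylethyl in place of trifluoromethoxy on an aromatic carbon. In words, 1-hydroxy-1-methylethyl stands in place of trifluoromethoxy on an aromatic carbon, para to a large group.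

Among the compounds with values here, only one measured step bears on this change, and it is small: a 1.8-fold higher number from compound 1 to compound 2 (0.26 log units; within the scatter). That step replaced a group on an aromatic carbon, but it involved no 1-hydroxy-1-methylethyl, so the data offer no direct measure of this group and point in no clear direction. No step beyond the scatter is therefore expected in this assay, although the uncertainty is wide. The estimated step is a 1.2-fold lower number from compound 2 to compound 3 (0.09 log units; within the scatter). For compound 3, the expected half-life is 2 h, with an estimated range of 0.9 h to 4.5 h.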

Compound 3, half-life: 20.2 h
The estimate for compound 3 lay 10-fold (1.00 log units) below the measured number; the measured number lies above the stated range.
By their numbers in this assay, from the lowest: compounds 1 and 2 (each within the scatter of the next); then compound 3.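

At this aromatic carbon, para to a large group, the earlier pair had shown no step beyond the scatter, so it was not yet clear that this place could move the half-life in this assay at all. Compound 3 shows that it can: 1-hydroxy-1-methylethyl in place of trifluoromethoxy gives an 8.2-fold higher number from compound 2 to compound 3 (0.91 log units; beyond the scatter), and the same group in place of the group with two four-membered rings gives a 15-fold higher number from compound 1 to compound 3 (1.18 log units; beyond the scatter), so on this shared core a single change at this place is enough to separate a compound from both earlier ones. No measurement among the data shown explains the rise.

From the compounds shown here alone, it remains open whether the hydroxyl of 1-hydroxy-1-methylethyl carries the step, which a tert-butyl group or a methyl ether of the same alcohol at this place would test. Going by these compounds, it is also open whether an amine or a carboxylic acid on this aromatic carbon would read like 1-hydroxy-1-methylethyl, and whether the step would hold on any other core.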